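Chain Length and Acyltransferase Inhibition in a Urea Series

The source may hold more compounds than are shown below. What is called first, only, known or untested is meant among the compounds shown, and "the series" means these compounds.

Three compounds have been measured in an assay on microsomes from intestine for inhibition of acyl-CoA:cholesterol acyltransferase (Oryctolagus cuniculus); a higher number here means a weaker inhibitor, a lower number a stronger inhibitor:

compound 1 `CCCCCCN1NN=C(NC(=O)Nc2c(C(C)C)cccc2C(C)C)N1`: 73 nM
compound 2 `CCCCCCCCCN1NN=C(NC(=O)Nc2c(C(C)C)cccc2C(C)C)N1`: 31 nM
compound 3 `CCCCCCCCCCN1NN=C(NC(=O)Nc2c(C(C)C)cccc2C(C)C)N1`: 14 nM

Compound 3 stands lowest of the three numbers; its nearest neighbour is compound 2, its furthest compound 1, and both steps to it lie beyond the scatter. Compound 4 `CCCCCCCCCCCCN1NN=C(NC(=O)Nc2c(C(C)C)cccc2C(C)C)N1` carries the change (ethyl in place of hydrogen on a saturated chain carbon, ten or more bonds along the chain from an amine nitrogen in a ring).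

Among the compounds with values here, three measured steps bear on this. Going up the chain, a 2.4-fold lower number from compound 1 to compound 2 (0.37 log units; beyond the scatter), a 5.2-fold lower number from compound 1 to compound 3 (0.72 log units; beyond the scatter) and a 2.2-fold lower number from compound 2 to compound 3 (0.35 log units; beyond the scatter), each a modest lowering and each beyond the scatter. Every lengthening of the chain seen so far has lowered the number, so a further modest lowering is expected in this assay for compound 4, though with only three points nothing shows whether the trend continues or levels off, so the range is kept wide. Compound 4 is therefore estimated at 8 nM, between 3.5 nM and 20 nM, which would be a step of a 1.8-fold lower number from compound 3 to compound 4 (0.24 log units; within the scatter).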

Compound 4, half-maximal inhibitory concentration: 14 nM
Beside the measured number, compound 4's estimate is 1.8-fold (0.24 log units) below it, within the range that was stated.
By their numbers in this assay, from the lowest: compounds 3 and 4 (each within the scatter of the next); then compound 2; then compound 1.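

In this assay the ethyl in place of hydrogen on a saturated chain carbon gives no change at the digits printed from compound 3 to compound 4 (within the scatter) and so does not extend the lowering seen with each earlier lengthening. The longer chain still holds all of the lowering already reached, with a 2.2-fold lower number from compound 2 to compound 4 (0.35 log units; beyond the scatter) and a 5.2-fold lower number from compound 1 to compound 4 (0.72 log units; beyond the scatter) on the same read-out. No measurement at hand offers an explanation for this result.

From the compounds shown here alone, whether a still longer chain would leave the number where it stands or raise it remains open. Also open, going by these compounds, is what a branched chain, or an amine or a carboxylic acid at the far end of the chain, would do at this position.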